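Stability in Buffer: From Compound 2 to Compound 3

This account rests on a few compounds, and the source may have more. Where it says the series, first, only, none or still open, it means among the compounds named here.

Of the compounds shown here, two that share one core have been measured in an ADME assay for pharmacokinetics, read by LC-MS, in phosphate buffer, with a stated time of 72 h, at pH 7.4, tested at 250 uM (on this read-out higher numbers stand for a longer-lived compound and lower numbers for a shorter-lived compound), so far. Compound 1 `C=CC(=O)Nc1cc(C(F)(F)F)cc(C(F)(F)F)c1` gives 5.7 h in this assay. Compound 2 `C=Cc1cc(C(F)(F)F)cc(C(F)(F)F)c1` reaches only a limit of this assay, > 50 h, so for compound 2 a range rather than a number is known, and it sits at the limit of > 50 h in this assay, at which 1 of the 2 values shown sits. Among the compounds with values here, the single step between them, an at least 8.7-fold higher number from compound 1 to compound 2 (0.94 log units; beyond the scatter), shows the change of vinyl in place of (vinylcarbonyl)amino on an aromatic carbon moving the half-life upward, beyond the scatter.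

Compound 3 `O=C(CBr)c1cc(C(F)(F)F)cc(C(F)(F)F)c1` has not yet been measured. It differs from compound 2 in one place: (bromomethyl)carbonyl in place of vinyl on an aromatic carbon. This change brings a carbonyl back onto the shared core, the reverse of what the measured step removed, so that step is the only one that bears on it and points downward. On that basis compound 3 is expected to show a shorter half-life than the limit seen for compound 2, a step of an at least 12-fold lower number from compound 2 to compound 3 (1.09 log units; beyond the scatter) in this assay. The estimate for compound 3 in this assay is 4 h, expected to lie between 1 h and 20 h.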

Compound 3, half-life: < 0.017 h
Compound 3: only a limit was reported; the forecaster's own chance of this, stated with the estimate: 10%; middle value at least 230-fold (2.37 log units) away from the limit.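

On an aromatic carbon meta to two trifluoromethyl groups, (bromomethyl)carbonyl in place of vinyl gives an at least 2900-fold lower number from compound 2 to compound 3 (3.46 log units; beyond the scatter) in this assay, and (bromomethyl)carbonyl in place of (vinylcarbonyl)amino gives an at least 330-fold lower number from compound 1 to compound 3 (2.52 log units; beyond the scatter). The earlier compounds had shown only that the half-life rose when vinyl took the place of (vinylcarbonyl)amino; the new result shows that the group on this same carbon can also take the half-life far down, to the short end of the read-out and well past the shorter-lived of the two earlier compounds. For compound 3 the read-out is a limit of the assay and not a number: the limit of < 0.017 h in this assay, at which 1 of the 3 values shown sits.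

Compound 2 also carries a limit and not a number, which leaves the exact size of the steps open: the limit of > 50 h in this assay, at which 1 of the 3 values shown sits. The compounds shown do not separate the part of the carbonyl from the part of the bromine, a question that an acetyl group, with the carbonyl and no bromine, or a chloroacetyl group, with chlorine on the same carbon, would bear on.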